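The source may report more compounds than this note shows. Statements on the series, on what has been measured and on what is new or still open speak of the compounds shown alone.

Working notes on the series. Of the compounds shown here, two of the shared core have been measured in a functional assay on the whole organism (Pleural cavity) for inhibition, with Rattus norvegicus as the target, at a dose of 25 mg/kg; on this read-out higher numbers stand for more inhibition at the one dose given (going by the name of the read-out) and lower numbers for less inhibition. Compound 1, `CSC1(C)C(=O)N(c2ccccc2)c2ncccc21`, gives 34% in this assay. Compound 2, `CC1(C)C(=O)N(Cc2ccc(Cl)cc2)c2ncccc21`, gives 6% in this assay. On these two numbers compound 1 stands highest, and the gap to compound 2 lies beyond the scatter; compound 2 differs from compound 1 in more than one place, so its number says nothing about either change on its own.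

Compound 3, `CCCCC1(C)C(=O)N(c2ccccc2)c2ncccc21`, is not yet measured. Its difference from compound 1 is butyl in place of methylsulfanyl on a saturated ring carbon. No measured pair isolates this change, so the expected step in this assay rests on no shown step. A small step from compound 1 to compound 3, downward or none beyond the scatter, is expected, as a number 6 percentage points lower from compound 1 to compound 3 (within the scatter). For compound 3 the estimate in this assay is 28%, with a range from 5% to 50%.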

Compound 3, a percentage reported as inhibition, in the whole organism at one dose (the size of the read-out at that dose, not a potency): 21%
Beside the measured number, compound 3's estimate is 7 percentage points above it, and the stated range covers the measured number.
By their numbers in this assay, from the lowest: compound 2; then compound 3; then compound 1.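

Among the compounds shown here, with butyl in place of methylsulfanyl on the saturated ring carbon, this assay shows a number 13 percentage points lower from compound 1 to compound 3 (beyond the scatter), the first step that isolates a single place. The read-out therefore responds to the group at this position, though the change is modest in size. Methylsulfanyl and butyl differ both in the sulfur atom and in the number of heavy atoms, so this one step cannot separate the two, and nothing available explains the drop.

Still open, as far as these compounds go, is how this carbon would respond to ethylsulfanyl, a methoxy group, an amine or a carboxylic acid. Also open, from the compounds shown here alone, is whether the step would hold with a group other than phenyl on the ring atom that bears it, such as benzyl.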